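Phenyl in place of ethoxy on the saturated ring carbon

The source may report more compounds than this note shows. Statements on the series, on what has been measured and on what is new or still open speak of the compounds shown alone.

Measured compounds in a functional assay on PC-3 cells (Homo sapiens) for inhibition, read by sulforhodamine B assay, with a stated time of 48 h; a higher number here means a weaker inhibitor, a lower number a stronger inhibitor:
compound 1, `CCO[C@H]1C[C@@H](c2coc3ccccc3c2=O)N(c2ccccc2)O1`, gives > 60000 nM
compound 2, `O=c1c([C@@H]2C[C@H](c3ccccc3)ON2c2ccccc2)coc2cc(Cl)c(Cl)cc12`, gives 32000 nM

Compound 1 stands at the limit of > 60000 nM in this assay, at which 1 of the 2 values shown sits; this is a limit of the assay, not a number. Compound 3, `O=c1c([C@@H]2C[C@H](c3ccccc3)ON2c2ccccc2)coc2ccccc12`, differs from compound 1 by phenyl in place of ethoxy on a saturated ring carbon. Within the data shown here, no step between measured compounds is available, and the value of compound 1 is only a limit, so compound 3 is expected to stay near or beyond it, giving an expected step of an at least 1.3-fold lower number from compound 1 to compound 3 (0.12 log units; that floor lies within the scatter) of no clear size. Compound 3 is therefore expected at about 45000 nM, with a range from 15000 nM to 150000 nM.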

Compound 3, half-maximal inhibitory concentration: > 60000 nM
Compound 3 gave a limit, no number; the forecaster's own chance of this, stated with the estimate: 55%; middle value at least 1.3-fold (0.12 log units) away from the limit.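

No step can be read from compound 1 to compound 3, since both results are limits and not numbers: the limit of > 60000 nM in this assay, at which 2 of the 3 values shown sit. The compounds shown leave open whether phenyl in place of ethoxy on a saturated ring carbon changes inhibition at all.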